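Sulfonamide series: chlorophenyl in place of hydroxyphenyl

The source may report more compounds than this note shows. Statements on the series, on what has been measured and on what is new or still open speak of the compounds shown alone.

Measured compounds:
compound 1 `O=S(=O)(Nc1ccc2oc(-c3ccccc3)nc2c1)c1ccccc1O` with 85000 nM
compound 2 `O=S(=O)(Nc1ccc(-c2nc3cc(NS(=O)(=O)c4ccccc4)ccc3o2)cc1)c1ccccc1` with 80000 nM
compound 3 `O=S(=O)(Nc1ccc(-c2nc3ccccc3o2)cc1)c1ccc(F)cc1` with 73000 nM

In an assay on cells for inhibition of HSP60/HSP10 (Homo sapiens), with a stated time of 60 min (a higher number here means a weaker inhibitor, a lower number a stronger inhibitor), compound 1 gives 85000 nM, the highest of the three numbers, yet both neighbours sit within the usual scatter of it: compound 2 gives 80000 nM and compound 3 gives 73000 nM. The three cannot be ordered against each other; all are weak inhibitors of a similar standing.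

Compound 4 `O=S(=O)(Nc1ccc2oc(-c3ccccc3)nc2c1)c1ccc(Cl)cc1` has not yet been measured. It differs from compound 1 in one place:

4-chlorophenyl in place of 2-hydroxyphenyl on a sulfonyl sulfur

Going by the values given here, no pair of measured compounds shows this change, so its size is not known from the series. Among the compounds with values here, the only related information is that compound 3, which carries a 4-fluorophenyl on its sulfonyl sulfur, gives 73000 nM, a number close to the others. Because compound 3 gives 73000 nM, no step beyond the scatter is expected here; a small step from compound 1 to compound 4 of a 1.2-fold lower number from compound 1 to compound 4 (0.08 log units; within the scatter) toward a slightly lower number is estimated. Compound 4 is therefore expected to give 70000 nM, in the range 30000 nM to 170000 nM.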

Compound 4, half-maximal inhibitory concentration: > 100000 nM
Compound 4 was reported as a limit; the forecaster's own chance of this, stated with the estimate: 20%; middle value at least 1.4-fold (0.15 log units) from the limit.
By their numbers in this assay, from the lowest: compounds 3, 2 and 1 (each within the scatter of the next). At a limit, above all of these: compound 4.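

In this assay compound 4 gives > 100000 nM, which is a limit of the assay and not a number. Exchanging the 2-hydroxyphenyl on the sulfonyl sulfur for a 4-chlorophenyl gives an at least 1.1-fold higher number from compound 1 to compound 4 (0.07 log units; that floor lies within the scatter), the first step read at this position, and it shows no gain in inhibition from a group with no hydrogen-bond donor or acceptor. This reading fixes only a floor for the step, and that floor depends on a single censored value: the limit of > 100000 nM in this assay, at which 1 of the 4 values shown sits.

How far compound 4 lies past its limit, and so whether the true step exceeds the scatter, cannot be read. Also open, as far as these compounds go, is whether an aminophenyl or a carboxyphenyl in place of the 2-hydroxyphenyl on the sulfonyl sulfur would give a clearly lower number.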